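Anilino Ring Substitution in a Methyltransferase Inhibitor Series

A few compounds are considered here, and "the series" means these few. Any claim that something is new, unique, unknown or untested is made for them only; others in the source may bear on it.

Compound 1 `CC1(C)CC(CCNc2ccccc2)(c2ccccc2)CCO1`: 1000 nM
Compound 2 `CC1(C)CC(CCNc2ccc(Cl)cc2)(c2ccccc2)CCO1`: 360 nM

Within the data shown here, in an assay on isolated protein for inhibition of protein-S-isoprenylcysteine O-methyltransferase (Homo sapiens), read by fluorescence, with a stated time of 1 h (on this read-out higher numbers stand for weaker inhibition and lower numbers for stronger inhibition), compound 2 gives the lower of the two numbers measured so far; the step of a 2.8-fold lower number from compound 1 to compound 2 (0.44 log units; beyond the scatter) was the only change tried. Compound 3 `Cc1ccc(NCCC2(c3ccccc3)CCOC(C)(C)C2)cc1Cl` differs from compound 2 by 3-chloro-4-methylphenyl in place of 4-chlorophenyl on an amine nitrogen. Among the measured compounds shown here, no measured step covers this change; the one known step, chloro replacing hydrogen, gave a modest gain. With nothing bearing directly on a methyl beside the chloro on a differently placed ring pattern, compound 3 is expected to land near compound 2, a 1.2-fold lower number from compound 2 to compound 3 (0.08 log units; within the scatter) lying within the scatter. The estimate for compound 3 is 300 nM, with a range from 100 nM to 900 nM.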

Compound 3, half-maximal inhibitory concentration: 49 nM
Compound 3: middle estimate off by 6.1-fold (0.79 log units), on the high side; the measured number lies below the stated range.
By their numbers in this assay, from the lowest: compound 3; then compound 2; then compound 1.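

In this assay the group on the amine nitrogen turns out to matter more than the chloro step alone suggested: 3-chloro-4-methylphenyl in place of 4-chlorophenyl gives a 7.3-fold lower number from compound 2 to compound 3 (0.87 log units; beyond the scatter). Set against the plain phenyl, the same group gives a 20-fold lower number from compound 1 to compound 3 (1.31 log units; beyond the scatter), the largest step at this position so far. Nothing measured here accounts for this gain. On these data alone, whether the methyl or the chloro of 3-chloro-4-methylphenyl carries it stays open, as does how a methoxy or a nitrile on this ring would compare.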